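A few compounds are considered here, and "the series" means these few. Any claim that something is new, unique, unknown or untested is made for them only; others in the source may bear on it.

Measured compounds and values in a functional assay on HeLa cells (Homo sapiens) for antiproliferative activity, read by MTT assay, with a stated time of 48 h; a higher number here means a weaker inhibitor, a lower number a stronger inhibitor:

Compound 1, `CNCC(=O)Nc1cc(OC)ccc1C(=O)c1ccc(OC)c2c1OC(C)(C)C=C2`, gives 870 nM.
Compound 2, `CNCC(=O)Nc1cc(OC)ccc1C(=O)c1ccc2c(c1)C=CC(C)(C)O2`, gives 970 nM.
Compound 3, `CCNCC(=O)Nc1cc(OC)ccc1C(=O)c1ccc(OC)c2c1OC(C)(C)C=C2`, gives 2690 nM.

Compound 1 and compound 2 carry different cores; the difference between the two cores is not broken down here. Their values in this assay lie within the scatter of each other, so nothing is said of their order.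

From compound 1 to compound 3 the change is methyl in place of hydrogen on a saturated chain carbon bound to an amine nitrogen. The step it made is a 3.1-fold higher number from compound 1 to compound 3 (0.49 log units; beyond the scatter). Compound 3 therefore stands apart from both compound 1 and compound 2, with compound 2 showing the lower number of the two cores against it.

Compound 4, `CCNCC(=O)Nc1cc(OC)ccc1C(=O)c1ccc2c(c1)C=CC(C)(C)O2`, is not yet measured. Against compound 2 it differs by methyl in place of hydrogen on a saturated chain carbon bound to an amine nitrogen, which is the same change, at the same place, as the one made from compound 1 to compound 3. The change occurs twice in the set and is measured once. Among the compounds with values here, with only one measured instance, and on a different core, the expectation rests on that single step alone.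

For compound 4 the step is expected to be about a 3.0-fold higher number from compound 2 to compound 4 (0.48 log units; beyond the scatter), resting on the step seen from compound 1 to compound 3, a 3.1-fold higher number from compound 1 to compound 3 (0.49 log units; beyond the scatter). Compound 4 is thus estimated at 2900 nM in this assay. For compound 4 the range is expected to run from 1300 nM to 6500 nM. The range is widened: the carry-over of the step from one core to the other has not been shown, and the starting point is what compound 2 gives, 970 nM.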

Compound 4, half-maximal inhibitory concentration: 3110 nM
Compound 4: middle estimate off by 1.1-fold (0.03 log units), on the low side; measured number inside the range.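

In this assay, methyl in place of hydrogen on a saturated chain carbon bound to an amine nitrogen, which turns methylamino into ethylamino, gave a 3.2-fold higher number from compound 2 to compound 4 (0.51 log units; beyond the scatter). Set beside the earlier instance, the step kept its direction and its size on the second core, and neither pair goes against it: the same change on two cores in this assay, a 3.1-fold higher number (0.49 log units; beyond the scatter) from compound 1 to compound 3 and a 3.2-fold higher number (0.51 log units; beyond the scatter) from compound 2 to compound 4, 1.0-fold (0.02 log units) apart, within the scatter of two such steps. This shows that the change carried over between the core of compound 1 and the core of compound 2 in this one assay, but two pairs do not show that it would carry over to any further core, and these numbers give no reason for the rise.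

The compounds shown leave open how the numbers run along the amine substituent beyond methylamino and ethylamino, for instance with the primary amine, a longer chain such as propyl, a branched group such as isopropyl, or a tertiary amine such as dimethylamino. They also leave open whether the same step would hold on a core carrying other groups, since the series here rests on just two cores and one read-out.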